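The compounds below may be only part of what the source reports. "The series", "measured", "known", "first", "only" and "open" are said of these compounds alone.

Measured so far in a functional assay on A549 cells (Homo sapiens) for inhibition, read by MTT assay, with a stated time of 24 h; on this read-out higher numbers stand for weaker inhibition and lower numbers for stronger inhibition:
compound 1, `CCOC(=O)C1=Cc2ccccc2OC1(OCc1cn(CC(=O)Nc2ccc(C)cc2)nn1)C(F)(F)F`: 54300 nM
compound 2, `CCOC(=O)C1=Cc2ccccc2OC1(OCc1cc(-c2ccc3ccccc3c2)no1)C(F)(F)F`: > 150000 nM

For the measured compounds named here, compound 1 is the only compound here with a number. For compound 2 the entry is a limit of the assay, not a number: the limit of > 150000 nM in this assay, at which 1 of the 2 values shown sits. Compound 3, `CCOC(=O)C1=Cc2ccccc2OC1(OCc1cn(-c2ccc([N+](=O)[O-])cc2)nn1)C(F)(F)F`, is not yet measured. It differs from compound 1 by 4-nitrophenyl in place of ((4-methylphenyl)carbamoyl)methyl on an aromatic nitrogen. Going by the values given here, no step between two measured compounds is known, so nothing shows how such a change moves the read-out. Compound 1 is taken as the reference, and the step of a 1.0-fold higher number from compound 1 to compound 3 (0.01 log units; within the scatter) is expected to stay within the usual scatter. Compound 3 is estimated at 55000 nM, within 20000 nM to 150000 nM.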

Compound 3, half-maximal inhibitory concentration: > 150000 nM
Compound 3 gave a limit, no number; the forecaster's own chance of this, stated with the estimate: 30%; middle value at least 2.7-fold (0.43 log units) away from the limit.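

For the compounds shown here, the nitrogen of the five-membered aromatic ring is the first position with a readable step: in this assay, 4-nitrophenyl in place of ((4-methylphenyl)carbamoyl)methyl gives an at least 2.7-fold higher number from compound 1 to compound 3 (0.44 log units; beyond the scatter). The read-out therefore responds to the group at this position, and this change weakens inhibition. The entry for compound 3 is a limit of the assay, not a number, so the full size of the step stays unknown: the limit of > 150000 nM in this assay, at which 2 of the 3 values shown sit.

On these data alone, the change swaps the whole group, so the part responsible for the step remains open. Also open, as far as these compounds go, is how a plain phenyl, a 4-aminophenyl or a carboxylic acid on this nitrogen would read.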